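Swapping the aryl group on the triazole: cytotoxicity outlook

The compounds below may be only part of what the source reports. "The series", "measured", "known", "first", "only" and "open" are said of these compounds alone.

Compound 1 `O=c1[nH]c(=O)n([C@H]2C[C@H](O)[C@@H](CO)O2)cc1-c1cn(-c2cc(F)cc(F)c2)nn1` is the starting point. Going by the values given here, in an ADME assay on HEL cells (Homo sapiens) for cytotoxicity, read by cell counting, with a stated time of 3 days (on this read-out lower numbers stand for higher toxicity in this test and higher numbers for lower toxicity in this test), compound 1 gives 220000 nM, and this is the only plain number in this data set. Compound 2 `O=c1[nH]c(=O)n([C@H]2C[C@H](O)[C@@H](CO)O2)cc1-c1cn(-c2ccc(Br)cc2)nn1` carries a 4-bromophenyl in place of the 3,5-difluorophenyl on an aromatic nitrogen. In this assay compound 2 is reported only as a limit, >= 44000 nM. The step from compound 1 to compound 2 therefore cannot be sized: a step that the limit leaves unreadable from compound 1 to compound 2.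

Compound 3 `CSc1ccc(-n2cc(-c3cn([C@H]4C[C@H](O)[C@@H](CO)O4)c(=O)[nH]c3=O)nn2)cc1` is not yet measured. It differs from compound 1 as follows: 4-(methylsulfanyl)phenyl in place of 3,5-difluorophenyl on an aromatic nitrogen. The only comparable step shown is the one to compound 2, and that one rests on (the limit of >= 44000 nM in this assay, at which 1 of the 2 values shown sits), so it gives no readable size or direction to lean on. A step of compound 3 in this assay of no more than the usual scatter is expected, a 1.8-fold lower number from compound 1 to compound 3 (0.26 log units; within the scatter). The estimate for compound 3 in this assay is 120000 nM, with a range from 40000 nM to 300000 nM.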

Compound 3, minimum cytotoxic concentration: > 230000 nM
Compound 3: only a limit was reported (the forecaster's own chance of this, stated with the estimate: 50%); middle value at least 1.9-fold (0.28 log units) from the limit.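

In this assay, 4-(methylsulfanyl)phenyl in place of 3,5-difluorophenyl on the aromatic nitrogen gives an at least 1.0-fold higher number from compound 1 to compound 3 (0.01 log units; that floor lies within the scatter). This is the first step at this position with a readable direction: the number for compound 3 does not fall below that of compound 1, so replacing both fluorines with a single sulfur-bearing group brings no sign of higher toxicity in this test, although the true size of the step stays hidden: the limit of > 230000 nM in this assay, at which 1 of the 3 values shown sits. The two steps that involve compound 2 still cannot be read, so the 4-bromophenyl group cannot be placed relative to either of the other aryl groups: the limit of >= 44000 nM in this assay, at which 1 of the 3 values shown sits.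

The compounds shown leave open where the true number for compound 3 lies, since its reported value is a limit and sets only a floor for the step. They also leave open how a phenyl group carrying an amine or a carboxylic acid on this aromatic nitrogen would read in this assay, as all three aryl groups shown carry only halogens or methylsulfanyl.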